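A few compounds are considered here, and "the series" means these few. Any claim that something is new, unique, unknown or untested is made for them only; others in the source may bear on it.

Measured in a functional assay on HL-60 cells (Homo sapiens) for inhibition, read by MTT assay, with a stated time of 48 h, tested at 10 uM; on this read-out lower numbers stand for less inhibition of growth and higher numbers for more inhibition of growth at the one concentration tested:
- compound 1 `Cc1cc(=O)c2c(O)cc(OC/C=C/c3ccccc3)c([C@H]3CCN(C)C[C@H]3O)c2o1`: 21%
- compound 2 `Cc1cc(=O)c2c(O)cc(OCc3ccco3)c([C@H]3CCN(C)C[C@H]3O)c2o1`: 32%
- compound 3 `Cc1cc(=O)c2c(O)c(CN3CCN(C(=O)OC(C)(C)C)CC3)c(O)c([C@H]3CCN(C)C[C@H]3O)c2o1`: 13%

Compound 3 gives 13%, which is within the scatter of compound 1 and beyond the scatter below compound 2. Compound 4 `CCOC(=O)N1CCN(Cc2c(O)c([C@H]3CCN(C)C[C@H]3O)c3oc(C)cc(=O)c3c2O)CC1` has ethyl in place of tert-butyl on an oxygen next to a carbonyl group. Going by the values given here, no measured step covers this exchange. The only one available, a number 11 percentage points higher from compound 1 to compound 2 (beyond the scatter), concerns a different group at a different place, so it offers only a rough guide to size. No step beyond the scatter is therefore expected in this assay, and no direction can be firmly assigned.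

The estimated step is a number 3 percentage points higher from compound 3 to compound 4 (within the scatter).

For compound 4 the expected value is 16%, with an estimated range of 5% to 30%.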

Compound 4, percent growth inhibition at one concentration: 16%
Compound 4: middle estimate and measured number agree at the digits printed; low and high end bracket the measured number.
By their numbers in this assay, from the lowest: compounds 3, 4 and 1 (each within the scatter of the next); then compound 2.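

In this assay, ethyl in place of tert-butyl on an oxygen next to a carbonyl group gives a number 3 percentage points higher from compound 3 to compound 4 (within the scatter). Going from 4 heavy atoms to 2 at this place therefore leaves the read-out within the scatter, the first information on this position, since the earlier step concerned a different group at a different place. No further measurement bears on this result. As far as these compounds go, whether a longer chain such as hexyl on this oxygen would give a step beyond the scatter remains open. The same holds for a free amine replacing the whole ethoxycarbonyl.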